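The source may hold more compounds than are shown below. What is called first, only, known or untested is meant among the compounds shown, and "the series" means these compounds.

Of the compounds shown here, two have so far been measured in a functional assay on DU-145 cells (Homo sapiens) for cytotoxicity, read by MTT assay; a higher number here means a weaker inhibitor, a lower number a stronger inhibitor. Compound 1 `CCCCC(CC(=O)O[C@H](CC=C(C)C)C1=CC(=O)c2c(O)ccc(O)c2C1=O)OC(C)=O` gives 67700 nM. Compound 2 `CC(C)=CC[C@@H](OCC(C)O)C1=CC(=O)c2c(O)ccc(O)c2C1=O` gives 16100 nM, the lower of the two numbers, with compound 1 standing above it by a gap beyond the scatter. Compound 3 `CC(C)=CC[C@@H](OC(=O)C1CCCCO1)C1=CC(=O)c2c(O)ccc(O)c2C1=O` remains to be measured in this assay. It differs from compound 2 in one place: (oxan-2-yl)carbonyl in place of 2-hydroxypropyl on an oxygen on a saturated carbon. Within the data shown here, no step between measured compounds is available for this change. From compound 1 and compound 2 alone, a modest rise in number is expected, a 1.7-fold higher number from compound 2 to compound 3 (0.24 log units; within the scatter), though a step within the scatter would also fit. Compound 3 is estimated at 28000 nM, between 9000 nM and 85000 nM.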

Compound 3, half-maximal inhibitory concentration: 24700 nM
Estimate against measurement, compound 3: 1.1-fold (0.05 log units) above; measured number inside the range.
By their numbers in this assay, from the lowest: compounds 2 and 3 (each within the scatter of the next); then compound 1.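

On the oxygen on a saturated carbon, replacing 2-hydroxypropyl with (oxan-2-yl)carbonyl in this assay gives a 1.5-fold higher number from compound 2 to compound 3 (0.19 log units; within the scatter) even though the entering group adds a ring and has no hydrogen-bond donor. With the carbonyl kept, oxan-2-yl in place of 2-acetoxyhexyl gives a 2.7-fold lower number from compound 1 to compound 3 (0.44 log units; beyond the scatter) and thus shows that the group on the carbonyl carbon can move the number beyond the scatter. No measured evidence accounts for either step.

Open, from the compounds shown here alone, is whether an amine or a carboxylic acid on this oxygen would shift the number beyond the scatter from compound 2. Also open, going by these compounds, is whether a simple acetyl group on this oxygen would stay within the scatter of compound 3.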